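The compounds below may be only part of what the source reports. "The series", "measured", "known", "first", "only" and "open" are said of these compounds alone.

In a functional assay on HepG2 cells (Homo sapiens) for antiproliferative activity, read by CCK-8 assay, with a stated time of 72 h, tested at 2 uM (on this read-out higher numbers stand for a stronger effect at the one concentration tested and lower numbers for a weaker effect), compound 1 `CC1CCN(c2nc(Cl)nc3c2ncn3Cc2ccc(/C=C/C(=O)Nc3ccccc3N)cc2)CC1` gives 8.73%. Among the three measured compounds this is the top number, yet the other two fall within the usual scatter of it: compound 2 `Nc1ccccc1NC(=O)c1ccc(Cn2cnc3c(NCc4ccccc4)nc(Cl)nc32)cc1` gives 7.55%, and compound 3 `CC(C)n1cnc2c(Nc3cccc(Cl)c3)nc(NCOCc3ccc(C(=O)Nc4ccccc4N)cc3)nc21` gives 1.48%, so no ordering among them can be claimed. Compound 4 `Nc1ccccc1NC(=O)/C=C/c1ccc(Cn2cnc3c(NC4CCCCC4)nc(Cl)nc32)cc1` has not yet been measured. It differs from compound 1 in one place (cyclohexylamino in place of 4-methylpiperidin-1-yl on an aromatic carbon), the two holding the same atoms joined differently. For the measured compounds named here, no step between measured compounds that differ in a single place is available, so this change has no direct precedent here. Because compound 1 gives 8.73% and the other measured numbers sit equally low, only a small step is expected, none beyond the scatter, a number 0.7 percentage points lower from compound 1 to compound 4 (within the scatter). Compound 4 is therefore estimated at 8%, with a range from 0% to 20%.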

Compound 4, a percentage reported as inhibition, at one concentration (the size of the read-out at that concentration, not a potency): 3.83%
Compound 4: the middle estimate sits 4.2 percentage points above what was measured, and the stated range covers the measured number.
By their numbers in this assay, from the lowest: compounds 3, 4, 2 and 1 (each within the scatter of the next).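

Swapping 4-methylpiperidin-1-yl for cyclohexylamino on this aromatic carbon in this assay gives a number 4.9 percentage points lower from compound 1 to compound 4 (within the scatter), the first single-place step available at this position. The swap adds a hydrogen-bond donor while keeping the heavy-atom count, yet at this one concentration the two compounds cannot be told apart. Nothing at hand offers an explanation for this result. As far as these compounds go, whether this position can shift the read-out beyond the scatter remains open. A morpholine ring or an open-chain amine such as dimethylamino at this carbon could help to settle that.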